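The compounds below may be only part of what the source reports. "The series", "measured", "known", "first", "only" and "open" are said of these compounds alone.

Working notes on the series. Compound 1 `Cc1nc(S(C)(=O)=O)ccc1Oc1ncnc(OC2CCN(C(=O)OC(C)F)CC2)c1F` and compound 2 `Cc1nc(S(C)(=O)=O)ccc1Oc1ncnc(OC2CCN(C(=O)SC(C)(C)C)CC2)c1F` share one core; they differ only in the group on the carbonyl carbon. In a functional assay on isolated protein for inhibition of Glucose-dependent insulinotropic receptor (Rattus norvegicus), read by HTRF and cAMP accumulation (on this read-out higher numbers stand for larger maximal responses and lower numbers for smaller maximal responses), compound 1 gives 68% and compound 2 gives 76%, so the measured step is a number 8 percentage points higher from compound 1 to compound 2 (within the scatter). Compound 2 therefore holds the higher of the two numbers, but the two values lie within the usual scatter, so no order between them is claimed.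

Compound 3 `Cc1nc(S(C)(=O)=O)ccc1Oc1ncnc(OC2CCN(C(=O)SC3CC3)CC2)c1F` is not yet measured. Its change relative to compound 2 is cyclopropyl in place of tert-butyl on a sulfur. Among the compounds with values here, the only measured step, the one from compound 1 to compound 2, touches the same carbonyl region and was itself small; it is the sole guide, and it suggests that exchanging the group attached to the sulfur leaves the maximal response largely where compound 2 put it. No step beyond the scatter is therefore expected, and the estimated step of a number 4 percentage points lower from compound 2 to compound 3 (within the scatter) is meant as a change within it. For compound 3 the expected value in this assay is 72%, with a range from 58% to 86%.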

Compound 3, largest response reached (reported as efficacy), in percent of the reference or control that the assay uses: 80%
The estimate for compound 3 lay 8 percentage points below the measured number, and the stated range covers the measured number.
By their numbers in this assay, from the lowest: compounds 1, 2 and 3 (each within the scatter of the next, the first and the last beyond it).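

In this assay, cyclopropyl in place of tert-butyl on a sulfur gives a number 4 percentage points higher from compound 2 to compound 3 (within the scatter) and thus no readable difference between the two groups at this place. Within the data shown here, the replacement of the whole group on the carbonyl carbon gives a number 12 percentage points higher from compound 1 to compound 3 (beyond the scatter) and is the first step to clear the scatter, though only modestly. This does not hold for every sulfur-linked group, as the step with tert-butyl on the sulfur, a number 8 percentage points higher from compound 1 to compound 2 (within the scatter), stays within the scatter. No available measurement accounts for these numbers.

Going by these compounds, the step from compound 1 to compound 3 changes the atom on the carbonyl carbon and the group behind it together, so the share of each stays open; an oxygen bearing cyclopropyl would separate the two. Also open, on these data alone, is how the maximal response behaves with a nitrogen on the carbonyl carbon, as in a dimethylamine-derived urea, or with a larger carbon ring such as cyclohexyl on the sulfur.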